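Changing the group on the ether oxygen of compound 3

The source may report more compounds than this note shows. Statements on the series, on what has been measured and on what is new or still open speak of the compounds shown alone.

In an ADME assay on microsomes from liver (Homo sapiens) for metabolic stability, read by LC-MS, tested at 1 uM (a lower number here means slower removal, a higher number faster removal of the compound), compound 3 `CC(C)(O)CN1CCC(Oc2ccc([C@H]3CC[C@]4(CC3)OOC3(O4)C4CC5CC(C4)CC3C5)cc2)CC1` gives 18 mL.min-1.g-1, and compound 2 `O=S(=O)(c1ccc([C@H]2CC[C@]3(CC2)OOC2(O3)C3CC4CC(C3)CC2C4)cc1)N1CCNCC1` gives 16 mL.min-1.g-1. These two lie within the scatter, as a 1.1-fold higher number from compound 2 to compound 3 (0.05 log units; within the scatter) shows. Compound 1 `NCCCCCOc1ccc([C@H]2CC[C@]3(CC2)OOC2(O3)C3CC4CC(C3)CC2C4)cc1` gives < 7 mL.min-1.g-1, which is a limit of the assay.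

Compound 4 `N[C@H]1CC[C@@H](Oc2ccc([C@H]3CC[C@]4(CC3)OOC3(O4)C4CC5CC(C4)CC3C5)cc2)CC1` carries 4-aminocyclohexyl in place of 1-(2-hydroxy-2-methylpropyl)piperidin-4-yl on an oxygen on an aromatic ring. Going by the values given here, the closest precedent is compound 1, which has 5-aminopentyl on that oxygen. Its change to the same piperidine group gave an at least 2.5-fold higher number from compound 1 to compound 3 (0.41 log units; beyond the scatter), beyond the scatter, and an at least 2.2-fold higher number from compound 1 to compound 2 (0.35 log units; beyond the scatter) is of similar size. Part of that step is expected to reverse, an estimated 1.8-fold lower number from compound 3 to compound 4 (0.26 log units; within the scatter). Compound 4 is expected at 10 mL.min-1.g-1, with an estimated range of 5 mL.min-1.g-1 to 20 mL.min-1.g-1.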

Compound 4, intrinsic clearance in microsomes: < 7 mL.min-1.g-1
Compound 4: no number, only a limit (the forecaster's own chance of this, stated with the estimate: 35%); at least 1.4-fold (0.15 log units) between middle value and limit.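

In this assay the ether oxygen tolerates a change of ring: 4-aminocyclohexyl in place of 1-(2-hydroxy-2-methylpropyl)piperidin-4-yl gives an at least 2.5-fold lower number from compound 3 to compound 4 (0.41 log units; beyond the scatter) and, against the sulfonyl compound, an at least 2.2-fold lower number from compound 2 to compound 4 (0.35 log units; beyond the scatter) as the measured steps. Compound 4 gives < 7 mL.min-1.g-1 as a limit of the assay, not a number. The step from compound 1 to compound 4 cannot be read, because both sit at that floor: the limit of < 7 mL.min-1.g-1 in this assay, at which 2 of the 4 values shown sit.

On these data alone, it remains open whether the higher number of compound 3 comes from its piperidine ring or from the 2-hydroxy-2-methylpropyl group on the ring nitrogen. A plain piperidin-4-yl on the same oxygen would separate the two.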